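Butyl in Place of tert-Butyl: Expected Cytotoxicity

The source may hold more compounds than are shown below. What is called first, only, known or untested is meant among the compounds shown, and "the series" means these compounds.

Compound 1 `CC(=O)OC[C@H]1O[C@@H](n2cc(-c3cc(-c4ccc(C(C)(C)C)cc4)no3)c(=O)[nH]c2=O)C[C@@H]1OC(C)=O` has the lower number of the two measured compounds: in a functional assay on ACHN cells (Homo sapiens) for cytotoxicity, read by sulforhodamine B assay, tested at 10 uM (a higher number here means more inhibition at the concentration tested (going by the name of the read-out), a lower number less inhibition), compound 1 gives 74.7%, while compound 2 `O=c1[nH]c(=O)n([C@H]2C[C@H](O)[C@@H](CO)O2)cc1-c1cn(Cc2ccccc2)nn1` reaches 98.7%, a gap beyond the usual scatter. Compound 3 `CCCCc1ccc(-c2cc(-c3cn([C@H]4C[C@H](OC(C)=O)[C@@H](COC(C)=O)O4)c(=O)[nH]c3=O)on2)cc1` differs from compound 1 in one place: butyl in place of tert-butyl on an aromatic carbon. Going by the values given here, no measured pair shows this change, so nothing here argues for a large shift. The step of a number 0.3 percentage points higher from compound 1 to compound 3 (within the scatter) is expected to stay within the scatter, with no clear direction. In this assay compound 3 is estimated at 75%, between 58% and 92%.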

Compound 3, a percentage reported as inhibition, at one concentration (the size of the read-out at that concentration, not a potency): 80.5%
Beside the measured number, compound 3's estimate is 5.5 percentage points below it; low and high end bracket the measured number.
By their numbers in this assay, from the lowest: compounds 1 and 3 (each within the scatter of the next); then compound 2.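

In this assay, going by these compounds alone, butyl in place of tert-butyl on an aromatic carbon gives a number 5.8 percentage points higher from compound 1 to compound 3 (within the scatter), the first measured pair for this change. At this place, on the six-membered aromatic ring, the two four-carbon groups therefore cannot be told apart in this read-out. Nothing measured here offers an explanation for this. As far as these compounds go, whether an amine, a carboxylic acid or a longer chain at the same place would give a similar reading remains open. So does whether a methyl group, or a bare ring carbon, would do so.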